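The source may hold more compounds than are shown below. What is called first, only, known or untested is meant among the compounds shown, and "the series" means these compounds.

Measured so far in a functional assay on L02 cells (Homo sapiens) for inhibition, read by Griess assay, with stated times of 1 h and 24 h; a lower number here means a stronger inhibitor, a higher number a weaker inhibitor:

- Compound 1 `CC(C)Nc1nc(/C=C/c2ccccc2)nc2ccsc12`: > 1000000 nM
- Compound 2 `CNc1nc(/C=C/c2ccccc2)nc2ccsc12`: > 1000000 nM
- Compound 3 `CCCCNc1nc(/C=C/c2ccccc2)nc2ccsc12`: > 1000000 nM

Each of these entries is a limit of this assay and not a true number. Compound 3 therefore has no exact place in the series. For the measured compounds named here, it shares its standing with the other two compounds, and the series so far comes down to the limit of > 1000000 nM in this assay, at which 3 of the 3 values shown sit.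

The next compound is compound 4 `CN1CCN(c2nc(/C=C/c3ccccc3)nc3ccsc23)CC1`. It keeps the core of compound 3 but changes the group on the aromatic carbon next to the ring nitrogen: 4-methylpiperazin-1-yl in place of butylamino on an aromatic carbon. In words, 4-methylpiperazin-1-yl stands in place of butylamino.

The measured steps offer little guidance. They are a step that the two limits leave unreadable from compound 1 to compound 2, a step that the two limits leave unreadable from compound 1 to compound 3 and a step that the two limits leave unreadable from compound 2 to compound 3. All three swap one chain on the nitrogen for another, none brings in a ring, and none has a readable size. They therefore set no expected size for this change.

The most likely outcome is that compound 4 also meets the limit, although a measurable value is possible, and that would mean stronger inhibition. The expected change is an at least 1.2-fold lower number from compound 3 to compound 4 (0.09 log units; that floor lies within the scatter). For compound 4 the estimated value is 800000 nM, with an expected range from 150000 nM to 1000000 nM.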

Compound 4, half-maximal inhibitory concentration: 198000 nM
The estimate for compound 4 lay 4.0-fold (0.61 log units) above the measured number; low and high end bracket the measured number.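

In this assay, for the compounds shown here, 4-methylpiperazin-1-yl on this aromatic carbon gives the only readable steps: an at least 5.0-fold lower number from compound 3 to compound 4 (0.70 log units; beyond the scatter), an at least 5.0-fold lower number from compound 2 to compound 4 (0.70 log units; beyond the scatter) and an at least 5.0-fold lower number from compound 1 to compound 4 (0.70 log units; beyond the scatter). The steps among compounds 1, 2 and 3 cannot be read, so swapping one open chain on the nitrogen for another shows nothing, whereas this change shows that the group at this position can move the number beyond the scatter. Even so, compound 4 gives 198000 nM. Most of the series still rests at the assay's limit: the limit of > 1000000 nM in this assay, at which 3 of the 4 values shown sit.

The change alters several things at once: a ring enters, the hydrogen-bond donor count goes from 1 to 0, and a second nitrogen comes in, and the compounds shown do not separate these features. As far as these compounds go, it remains open whether a piperidine, with its ring but no second ring nitrogen, a morpholine, with oxygen in place of that nitrogen, or a piperazine without the methyl group would give a lower number, the same number or a return to the limit.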